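The source may report more compounds than this note shows. Statements on the series, on what has been measured and on what is new or still open speak of the compounds shown alone.

Measured compounds:
- Compound 1 `CCOc1cccc(/C=N/c2c(C)n(C)n(-c3ccccc3)c2=O)c1`: in a functional assay on DLD-1 cells (Homo sapiens) for cytotoxicity, read by MTT assay, with a stated time of 72 h (a higher number here means a weaker inhibitor, a lower number a stronger inhibitor), compound 1 gives 724000000 nM
- Compound 2 `COc1ccc(/C=N/c2c(C)n(C)n(-c3ccccc3)c2=O)cc1`: in this assay compound 2 gives 977000000 nM
- Compound 3 `Cc1c(/N=C/c2cccc(O)c2)c(=O)n(-c2ccccc2)n1C`: in this assay compound 3 gives 372000000 nM

All three share one core and differ only in the aromatic ring attached to the carbon with a double bond to nitrogen. Compound 3 stands at the low end of the three numbers: one gap is small a 1.9-fold lower number from compound 1 to compound 3 (0.29 log units; within the scatter), the other is modest a 2.6-fold lower number from compound 2 to compound 3 (0.42 log units; beyond the scatter). Compound 4 `Cc1c(/N=C/c2ccccc2Cl)c(=O)n(-c2ccccc2)n1C` carries 2-chlorophenyl in place of 3-hydroxyphenyl on a carbon with a double bond to nitrogen. Going by the values given here, no measured step exchanges a hydroxyl for a chlorine, so the two steps above, which change the substituent on that same ring and shift the number only a little, are the nearest guide. Both suggest that swapping one substituent on this ring for another moves the number by a modest amount at most. The expected step from compound 3 to compound 4 in this assay is therefore a 1.3-fold higher number from compound 3 to compound 4 (0.13 log units; within the scatter), no direction beyond the scatter. Compound 4 is estimated at 500000000 nM, within 200000000 nM to 1500000000 nM.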

Compound 4, half-maximal inhibitory concentration: 417000000 nM
For compound 4 the middle estimate is 1.2-fold (0.08 log units) above the measured one, and the stated range covers the measured number.
By their numbers in this assay, from the lowest: compounds 3, 4, 1 and 2 (each within the scatter of the next, the first and the last beyond it).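

In this assay the 2-chlorophenyl group, with 0 hydrogen-bond donors and 0 hydrogen-bond acceptors, replaces the 3-hydroxyphenyl group and gives a 1.1-fold higher number from compound 3 to compound 4 (0.05 log units; within the scatter), so the hydroxyl is not needed to keep the number where compound 3 has it. Compound 4 also shows that a ring bearing no oxygen can stand apart from the 4-methoxyphenyl ring, with a 2.3-fold lower number from compound 2 to compound 4 (0.37 log units; beyond the scatter) as a modest step beyond the scatter. No measurement is available to explain either step.

The 3-hydroxyphenyl and 2-chlorophenyl groups differ in both the substituent and its place on the ring, so these two effects cannot be separated. As far as these compounds go, whether an amine or a carboxylic acid on this ring would move the number further remains open.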